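The source may report more compounds than this note shows. Statements on the series, on what has been measured and on what is new or still open speak of the compounds shown alone.

In a functional assay on SNB-19 cells (Homo sapiens) for inhibition, read by sulforhodamine B assay, with a stated time of 48 h (on this read-out lower numbers stand for higher toxicity in this test and higher numbers for lower toxicity in this test), three compounds built on a shared core have been tested, and not one of them returned a number. Compound 1 `O=C(Nc1cccc(-n2cc(-c3ccncc3)c(-c3ccc(Cl)c(O)c3)n2)c1)Nc1ccc(Cl)c(Cl)c1` gave only a limit of the assay, > 32500 nM. Compound 2 `COc1cc(-c2nn(-c3cccc(NC(=O)c4cccc(C(F)(F)F)c4)c3)cc2-c2ccncc2)ccc1Cl` also gave only a limit, > 50000 nM. Compound 3 `COc1cc(-c2nn(-c3cccc(NC(=O)Nc4cccc(C(F)(F)F)c4)c3)cc2-c2ccncc2)ccc1Cl` likewise gave only a limit, > 50000 nM. Compound 3 thus sits at the limit of > 50000 nM in this assay, at which 2 of the 3 values shown sit, as does compound 2, while compound 1 sits at the limit of > 32500 nM in this assay, at which 1 of the 3 values shown sits. Compound 4 `COc1cc(-c2nn(-c3cccc(NC(=O)c4ccccc4)c3)cc2-c2ccncc2)ccc1Cl` has not yet been measured; it differs from compound 3 by phenyl in place of (3-(trifluoromethyl)phenyl)amino on a carbonyl carbon. Going by the values given here, the one measured step that touches this change is a step that the two limits leave unreadable from compound 2 to compound 3, which the two limits leave unreadable. With no readable step and every value a limit, there is no basis for expecting a shift in either direction beyond the scatter. Compound 4 is therefore expected to give 60000 nM, within a range from 20000 nM to 200000 nM, most probably again only as a limit. The step expected from this estimate is a step that the limit leaves unreadable from compound 3 to compound 4.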

Compound 4, concentration lethal to 50% of the cells: > 100000 nM
Compound 4: only a limit was reported; the forecaster's own chance of this, stated with the estimate: 85%; middle value at least 1.6-fold (0.22 log units) away from the limit.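

Compound 4 also gave only a limit in this assay, so its steps from compound 2 and compound 3 cannot be read. The compounds shown leave open what number any of them would return, and so whether either change alters the value at all.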